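Methyl to Bromo on the Aniline Ring: Expecting No Real Shift

The source may hold more compounds than are shown below. What is called first, only, known or untested is meant among the compounds shown, and "the series" means these compounds.

Three compounds have been measured in an assay on isolated protein for inhibition of Myc proto-oncogene protein (Homo sapiens), read by mobility shift assay, tested at 100 uM; a higher number here means more inhibition at the concentration tested (going by the name of the read-out), a lower number less inhibition:

Compound 1, `O=[N+]([O-])c1ccc(Nc2ccccc2)c2nonc12`, gives 2%.
Compound 2, `O=[N+]([O-])c1ccc(N2CCCCC2)c2nonc12`, gives 10%.
Compound 3, `Cc1ccccc1Nc1ccc([N+](=O)[O-])c2nonc12`, gives 11%.

Among these three values, the number for compound 3 is the highest, but that ranking carries little weight: compound 2 and compound 1 both sit within the usual scatter of it, so none of the three can be told apart with confidence. All three numbers are small, meaning that at the concentration tested little inhibition is seen for any of them.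

Compound 4, `O=[N+]([O-])c1ccc(Nc2ccccc2Br)c2nonc12`, has not yet been measured. It differs from compound 3 in one place: bromo in place of methyl on an aromatic carbon.

Among the compounds with values here, only one measured step bears on this change. Going a number 9 percentage points higher from compound 1 to compound 3 (within the scatter) shows that adding a methyl at this position did not move the read-out beyond the scatter. The change to compound 4 keeps a single heavy atom at the same position, with no ring, no charge and no donors or acceptors added or removed, so nothing in the measured data suggests a sizeable step. Compound 4 is therefore expected to give 10%, within a range of 1% to 22%, which means an expected step of a number 1 percentage points lower from compound 3 to compound 4 (within the scatter), not beyond the scatter.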

Compound 4, a percentage reported as inhibition, at one concentration (the size of the read-out at that concentration, not a potency): 39%
Compound 4: middle estimate off by 29 percentage points, on the low side; the measured number lies above the stated range.
By their numbers in this assay, from the lowest: compounds 1, 2 and 3 (each within the scatter of the next); then compound 4.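

In this assay, within the data shown here, this place on the aniline ring proves more sensitive than the earlier compounds suggested: bromo in place of methyl gives a number 28 percentage points higher from compound 3 to compound 4 (beyond the scatter) even though one heavy atom simply replaces another, with no change in rings, net charge, or hydrogen-bond donors and acceptors. Bromo in place of hydrogen gives a number 37 percentage points higher from compound 1 to compound 4 (beyond the scatter) whereas methyl in place of hydrogen gives only a number 9 percentage points higher from compound 1 to compound 3 (within the scatter) and so the two groups, each a single heavy atom on the same aromatic carbon, are not interchangeable in this series. No measurement among those shown explains why bromo and methyl differ here.

As far as these compounds go, whether chloro or iodo at this place would read like bromo or like methyl remains open, as does the outcome with a methoxy group or an amine there. It is also unknown whether bromo on another carbon of the same ring would give a similar number, and a reading at a single concentration cannot show how potent compound 4 is.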